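A Switch of Aryl Groups on the Sulfonyl Sulfur

This account rests on a few compounds, and the source may have more. Where it says the series, first, only, none or still open, it means among the compounds named here.

Of the compounds shown here, three have been measured in an assay on HeLa cells for displacement of a labelled ligand from 5-hydroxytryptamine receptor 6 (Homo sapiens); a higher number here means a weaker inhibitor, a lower number a stronger inhibitor. Compound 1, `CN1CCN(c2ccc3[nH]nc(S(=O)(=O)c4ccccc4Cl)c3c2)CC1`, gives 4 nM, the lowest of the three numbers, and it is the strongest inhibitor shown, since both other compounds stand beyond the usual scatter from it. Compound 2, `O=S(=O)(c1cccc2ccccc12)c1n[nH]c2cc(N3CCNCC3)ccc12`, gives 22 nM in this assay, and compound 3, `O=S(=O)(c1cccc(F)c1)c1n[nH]c2cccc(N3CCNCC3)c12`, gives 134 nM. No two of these differ in only one place, so none of them shows what a single change does.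

Compound 4, `Cc1ccc(S(=O)(=O)c2n[nH]c3ccc(N4CCN(C)CC4)cc23)cc1`, has not yet been measured. It differs from compound 1 by one change: 4-methylphenyl in place of 2-chlorophenyl on a sulfonyl sulfur. Nothing measured here shows how exchanging one aromatic ring for another on the sulfonyl sulfur changes the result; the shared core and the remaining groups of compound 1 are kept. A small step is expected, a 2.0-fold higher number from compound 1 to compound 4 (0.30 log units; within the scatter), toward a slightly higher number, possibly within the scatter. Compound 4 is therefore expected to give about 8 nM in this assay, in a range of 3 nM to 25 nM.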

Compound 4, inhibition constant: 4.9 nM
Beside the measured number, compound 4's estimate is 1.6-fold (0.21 log units) above it; the measured number falls inside the stated range.
By their numbers in this assay, from the lowest: compounds 1 and 4 (each within the scatter of the next); then compound 2; then compound 3.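

In this assay, among the compounds shown here, 4-methylphenyl in place of 2-chlorophenyl on the sulfonyl sulfur gives a 1.2-fold higher number from compound 1 to compound 4 (0.09 log units; within the scatter), the first comparison here in which only one place differs. With the shared core and the remaining groups kept, these two aromatic rings cannot be told apart in this assay, so the chlorine of one and the methyl of the other need not decide the result in this pair. No supporting measurement bears on this result.

The compounds shown leave open whether a ring that holds nitrogen, such as pyridine, or a non-aromatic group, such as cyclohexyl, would keep the number close to that of compound 1. They also leave open what an amine or a carboxylic acid on the aromatic ring would do.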